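Butyl for tert-butyl: step from compound 3 to compound 4

The source may report more compounds than this note shows. Statements on the series, on what has been measured and on what is new or still open speak of the compounds shown alone.

compound 1 `CN(C)c1ccc(C(=O)N(CCCCCC(=O)NO)CC(=O)NC2CCCCC2)cc1`: 2970 nM
compound 2 `CC(C)(C)NC(=O)CN(CCCCCC(=O)NO)C(=O)c1ccccc1`: 16700 nM
compound 3 `CN(C)c1ccc(C(=O)N(CCCCCC(=O)NO)CC(=O)NC(C)(C)C)cc1`: 4040 nM

In a functional assay on CAL-27 cells (Homo sapiens) for cytotoxicity, read by MTT assay, with a stated time of 72 h (on this read-out higher numbers stand for weaker inhibition and lower numbers for stronger inhibition), compound 3 stands at 4040 nM. Its smallest step to another measured compound is a 1.4-fold higher number from compound 1 to compound 3 (0.13 log units; within the scatter), and its largest is a 4.1-fold lower number from compound 2 to compound 3 (0.62 log units; beyond the scatter).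

Compound 4 `CCCCNC(=O)CN(CCCCCC(=O)NO)C(=O)c1ccc(N(C)C)cc1` is the next case: butyl in place of tert-butyl on an amide-type nitrogen. This is butyl in place of tert-butyl on an amide-type nitrogen, with the dimethylamino group retained.

Among the compounds with values here, the one measured step at this nitrogen is a 1.4-fold higher number from compound 1 to compound 3 (0.13 log units; within the scatter), so a change of group there has so far stayed small. The step of a 4.1-fold lower number from compound 2 to compound 3 (0.62 log units; beyond the scatter) concerns the aromatic carbon, which does not change here, and it offers no guide. Within the data shown here, no measured compound carries butyl at this nitrogen, so the expectation rests on a single comparison.

No step beyond the scatter is expected, and the estimated change is a 1.1-fold lower number from compound 3 to compound 4 (0.03 log units; within the scatter). For compound 4 the expected value is 3800 nM, with an estimated range of 1800 nM to 8000 nM.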

Compound 4, half-maximal inhibitory concentration: 1870 nM
Estimate against measurement, compound 4: 2.0-fold (0.31 log units) above, within the range that was stated.
By their numbers in this assay, from the lowest: compounds 4, 1 and 3 (each within the scatter of the next, the first and the last beyond it); then compound 2.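

In this assay the amide-type nitrogen now shows a step beyond the scatter: the exchange of tert-butyl for butyl, the same atoms joined differently, gives a 2.2-fold lower number from compound 3 to compound 4 (0.33 log units; beyond the scatter) and so moves the number modestly, where the earlier step at this position did not leave the scatter. The exchange of cyclohexyl for butyl gives a 1.6-fold lower number from compound 1 to compound 4 (0.20 log units; within the scatter) and stays within the scatter, so these two groups are not separated at this position. No measured property is available to explain either step.

As far as these compounds go, it remains open whether a longer chain such as hexyl, or a chain ending in an amine or a carboxylic acid, would follow butyl at this nitrogen. From the compounds shown here alone, it is also open whether the butyl step holds with hydrogen in place of dimethylamino on the aromatic carbon.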